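A few compounds are considered here, and "the series" means these few. Any claim that something is new, unique, unknown or untested is made for them only; others in the source may bear on it.

Measured in an ADME assay on MT4 cells (Homo sapiens) for cytotoxicity, read by MTT assay, with a stated time of 5 days; a lower number here means that less compound is tolerated, a higher number that more compound is tolerated:

- Compound 1 `Cc1cc(/C=C/C#N)cc(C)c1Oc1cc(NCCN(C)C)nc(Nc2ccc(C#N)cc2)c1`: 4270 nM
- Compound 2 `Cc1cc(/C=C/C#N)cc(C)c1Oc1cc(NCCN2CCNCC2)nc(Nc2ccc(C#N)cc2)n1`: 3650 nM
- Compound 3 `Cc1cc(/C=C/C#N)cc(C)c1Oc1cc(NCC2CCCO2)nc(Nc2ccc(C#N)cc2)n1`: > 268000 nM, a limit of the assay and not a number

Among the measured compounds shown here, the values of compound 1 and compound 2 lie within the scatter of each other, so compound 1 stands level with the only other true number available.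

Compound 4 `Cc1cc(/C=C/C#N)cc(C)c1Oc1cc(Cl)nc(Nc2ccc(C#N)cc2)c1` has not yet been measured. It carries chloro in place of (2-(dimethylamino)ethyl)amino on an aromatic carbon, next to the ring nitrogen (chloro in place of (2-(dimethylamino)ethyl)amino on an aromatic carbon).

For the measured compounds named here, only one measured step bears on this change: an at least 73-fold higher number from compound 2 to compound 3 (1.86 log units; beyond the scatter). There, a chain ending in piperazin-1-yl gives way to one ending in oxolan-2-yl. That step is large, but it is an imperfect guide. It is a different swap, and the core of compound 1 is not quite that of compound 2. Compound 4 likewise loses a chain with an amino end, so a clear rise in this assay is expected, though perhaps a smaller one than that single step suggests. The expected change is a 7.0-fold higher number from compound 1 to compound 4 (0.85 log units; beyond the scatter). For compound 4, the estimated value is 30000 nM, with an expected range of 7000 nM to 200000 nM.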

Compound 4, half-maximal cytotoxic concentration: > 311000 nM
Compound 4 gave a limit, no number (the forecaster's own chance of this, stated with the estimate: 35%); middle value at least 10-fold (1.01 log units) from the limit.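

In this assay, replacing the whole chain with a single chloro on the core of this series gives an at least 72-fold higher number from compound 1 to compound 4 (1.86 log units; beyond the scatter), so the large rise no longer rests only on a swap of one chain for another on the core of compound 2. Compound 4 gives a limit of the assay and not a number: the limit of > 311000 nM in this assay, at which 1 of the 4 values shown sits.

Across the four compounds shown, the chains with an amino end, in compound 1 and compound 2, go with true numbers, while compound 3 and compound 4, which have no such end, go with limits, and none of the four goes against this pattern.

On these data alone, with limits at the top of the scale, the full size of the step stays unknown, and compound 3 and compound 4 cannot be ranked against each other. Also open, as far as these compounds go, is whether the amino end or the chain as a whole drives the change, which a plain butyl chain or a chain ending in a carboxylic acid on this same aromatic carbon could begin to separate.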